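The source may report more compounds than this note shows. Statements on the series, on what has been measured and on what is new or still open speak of the compounds shown alone.

Compound 1 `Brc1cn2ccnc2c(-c2ccc3ncn(C4CCCCC4)c3c2)n1`: 8.09%
Compound 2 `c1ccc2c(-c3cn4ccnc4c(-c4ccc5ncn(C6CCCCC6)c5c4)n3)cccc2c1`: 9.08%

In a functional assay on SNB-19 cells (Homo sapiens) for inhibition, read by sulforhodamine B assay, with a stated time of 48 h, tested at 10 uM (a higher number here means more inhibition at the concentration tested (going by the name of the read-out), a lower number less inhibition), compound 2 stands highest of the two numbers, with compound 1 nearest, the step of a number 1 percentage points higher from compound 1 to compound 2 (within the scatter) lying within the scatter. Compound 3 `Brc1ccc(-c2cn3ccnc3c(-c3ccc4ncn(C5CCCCC5)c4c3)n2)cc1` differs from compound 2 by 4-bromophenyl in place of naphthalen-1-yl on an aromatic carbon. For the measured compounds named here, the one measured step bears on this only loosely: from compound 1 to compound 2 a bromo group gave way to naphthalen-1-yl and the number barely moved. With 4-bromophenyl now entering, the step in this assay is expected to be a number 0.6 percentage points lower from compound 2 to compound 3 (within the scatter), none beyond the scatter. Compound 3 is therefore estimated at 8.5%, within a range from 0% to 20%.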

Compound 3, a percentage reported as inhibition, at one concentration (the size of the read-out at that concentration, not a potency): 18.3%
Estimate against measurement, compound 3: 9.8 percentage points below; low and high end bracket the measured number.
By their numbers in this assay, from the lowest: compounds 1, 2 and 3 (each within the scatter of the next, the first and the last beyond it).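

In this assay, for the compounds shown here, replacing bromo with 4-bromophenyl gives a number 10.2 percentage points higher from compound 1 to compound 3 (beyond the scatter) and is the first step at this aromatic carbon to clear the usual scatter, though only modestly. Measured against naphthalen-1-yl, the same group gives a number 9.2 percentage points higher from compound 2 to compound 3 (within the scatter) and so cannot be told apart from it here. Nothing available explains either step. Still open, going by these compounds, is whether a plain phenyl, or a phenyl carrying an amine or a carboxylic acid in place of the bromine, would shift the number further at this position.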